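Aryl substituent changes in the lactam amide series

The source may hold more compounds than are shown below. What is called first, only, known or untested is meant among the compounds shown, and "the series" means these compounds.

Measured so far, in a functional assay on MGC-803 cells (Homo sapiens) for antiproliferative activity, read by MTT assay, with a stated time of 72 h; on this read-out higher numbers stand for weaker inhibition and lower numbers for stronger inhibition:
compound 1 `O=C(COc1ccc(C(=O)/C=C/c2cccc(Br)c2)cc1)N[C@H]1CCOC1=O` — 11900 nM
compound 2 `CC(C)c1ccc(/C=C/C(=O)c2ccc(OCC(=O)N[C@H]3CCOC3=O)cc2)cc1` — 16800 nM
compound 3 `O=C(CNc1ccccc1Cl)N[C@H]1CCOC1=O` — > 64000 nM, a limit of the assay, not a number

Compound 2 stands highest of the two numbers shown; the gap to its nearest number, a 1.4-fold higher number from compound 1 to compound 2 (0.15 log units; within the scatter), lies within the scatter, so no order is claimed. Compound 4 `O=C(COc1ccc(C(=O)/C=C/c2ccccc2)cc1)N[C@H]1CCOC1=O` carries the change (hydrogen in place of isopropyl on an aromatic carbon). For the measured compounds named here, the one measured step that bears on it, a 1.4-fold higher number from compound 1 to compound 2 (0.15 log units; within the scatter), also swaps the group on that aromatic ring and stays within the scatter. The expected step is therefore a 1.3-fold lower number from compound 2 to compound 4 (0.11 log units; within the scatter), no change beyond the scatter in either direction. Compound 4 is estimated at 13000 nM, with a range from 6000 nM to 30000 nM.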

Compound 4, half-maximal inhibitory concentration: > 64000 nM
Compound 4: no number, only a limit; the forecaster's own chance of this, stated with the estimate: 5%; middle value at least 4.9-fold (0.69 log units) from the limit.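

In this assay, hydrogen in place of isopropyl gives an at least 3.8-fold higher number from compound 2 to compound 4 (0.58 log units; beyond the scatter), and hydrogen in place of bromo gives an at least 5.3-fold higher number from compound 1 to compound 4 (0.73 log units; beyond the scatter). Compound 4 gives a limit of the assay, not a number: the limit of > 64000 nM in this assay, at which 2 of the 4 values shown sit.

The earlier swap between 3-bromophenyl and 4-isopropylphenyl stayed within the scatter, whereas plain phenyl now separates from both, so having a group on this ring matters more than which of these two it is. Going by these compounds, the full size of both steps stays open, since they rest on a limit. Also open, on these data alone, is what an amine or a carboxylic acid on this aromatic carbon would give.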